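The compounds below may be only part of what the source reports. "The series", "measured", "known", "first", "only" and "open" are said of these compounds alone.

Three compounds share one core and differ only in the groups on its two aromatic rings. Compound 1 `COc1ccc(-c2nnc(SCC(=O)c3ccccc3)n2-c2ccccc2)cc1OC` carries a phenyl on an aromatic nitrogen and two methoxy groups on the other ring; in a functional assay on the whole organism (strain albino) for inhibition, with Rattus norvegicus as the target, read by paw edema, with a stated time of 2 h, at a dose of 0.28 mmol/kg by the oral route (on this read-out higher numbers stand for more inhibition at the one dose given (going by the name of the read-out) and lower numbers for less inhibition), compound 1 gives 57%. Compound 2 `C=CCn1c(SCC(=O)c2ccccc2)nnc1-c1ccc(OC)c(OC)c1` carries an allyl in place of that phenyl, and in this assay compound 2 gives 63%. Compound 3 `C=CCn1c(SCC(=O)c2ccccc2)nnc1-c1ccc(OC)cc1` keeps the allyl but has a hydrogen in place of one methoxy; in this assay compound 3 gives 53%. On these numbers compound 2 stands highest of the three, but both steps leading to it lie within the scatter: a number 6 percentage points higher from compound 1 to compound 2 (within the scatter) and a number 10 percentage points lower from compound 2 to compound 3 (within the scatter). The number for compound 2 therefore cannot be called higher than those of the other two beyond the scatter.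

Compound 4 `C=CCn1c(SCC(=O)c2ccccc2)nnc1-c1cc(OC)c(OC)c(OC)c1` has not yet been measured. It differs from compound 2 in one place: methoxy in place of hydrogen on an aromatic carbon. Among the compounds with values here, the only measured step that bears on this change is a number 10 percentage points lower from compound 2 to compound 3 (within the scatter), which runs in the opposite sense, removing a methoxy rather than adding one, and stayed within the scatter. An added methoxy is accordingly expected to give at most a small rise, a number 3 percentage points higher from compound 2 to compound 4 (within the scatter), not beyond the scatter. In this assay compound 4 is estimated at 66%, with a range from 53% to 79%.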

Compound 4, a percentage reported as inhibition, in the whole organism at one dose (the size of the read-out at that dose, not a potency): 62%
Compound 4: middle estimate off by 4 percentage points, on the high side, and the stated range covers the measured number.
By their numbers in this assay, from the lowest: compounds 3, 1, 4 and 2 (each within the scatter of the next).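

In this assay the step for methoxy in place of hydrogen on this aromatic carbon, ortho to a methoxy group and meta to another, is a number 1 percentage points lower from compound 2 to compound 4 (within the scatter) and so cannot be told from repeat measurement, which means this carbon of the ring can carry a methoxy with no difference that the read-out can resolve. The earlier step on this ring, a number 10 percentage points lower from compound 2 to compound 3 (within the scatter) and likewise inside the usual spread, concerned the loss of a methoxy at a different carbon, so compounds 3, 2 and 4 together give no trend with the number of methoxy groups on the ring, in either sense. No information is available that would explain the result at this position.

The compounds shown leave open whether a group other than methoxy on this carbon, such as a hydroxy, a fluorine or an amine, would give a number that stands clear of compound 2 in this assay. They also leave open whether the same added methoxy would behave alike with the phenyl of compound 1 on the aromatic nitrogen in place of the allyl.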